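The source may hold more compounds than are shown below. What is called first, only, known or untested is meant among the compounds shown, and "the series" means these compounds.

Compound 1 `Cc1nc(-c2ccccc2F)sc1C(=O)NC/C=C/S(C)(=O)=O`: 69000 nM
Compound 2 `COC(=O)/C=C/CNC(=O)c1cc(-c2ccc(C)cc2)on1`: > 150000 nM

In an ADME assay on HepG2 cells (Homo sapiens) for cytotoxicity, read by MTT assay, with a stated time of 72 h (a lower number here means a stronger inhibitor, a higher number a weaker inhibitor), compound 1 gives a measured number of 69000 nM. Compound 2 stands only at a limit, > 150000 nM, which is a limit of the assay and not a number. The two compounds differ in more than one place, so no single step can be read from them.

Compound 3 `Cc1ccc(-c2cc(C(=O)NC/C=C/S(C)(=O)=O)no2)cc1` departs from compound 2 by one change, methylsulfonyl in place of methoxycarbonyl on a double-bonded chain carbon bound to a double-bonded chain carbon. Compound 1 carries the same 2-(methylsulfonyl)ethenyl and gives 69000 nM, which points to a modest move towards stronger inhibition in this assay. The expected size of the estimated change is an at least 1.6-fold lower number from compound 2 to compound 3 (0.22 log units; that floor lies within the scatter). Compound 3 is expected at 90000 nM, with an estimated range of 35000 nM to 220000 nM.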

Compound 3, half-maximal inhibitory concentration: 76000 nM
The estimate for compound 3 lay 1.2-fold (0.07 log units) above the measured number, and the stated range covers the measured number.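

In this assay, among these compounds, the exchange of methoxycarbonyl for methylsulfonyl on a double-bonded chain carbon bound to a double-bonded chain carbon gives the first step that can be read here: an at least 1.9-fold lower number from compound 2 to compound 3 (0.29 log units; that floor lies within the scatter). Since this is only a floor and it lies within the scatter, it does not by itself establish a change of real size. The true size stays unknown, as compound 2 gives only a limit and not a number: the limit of > 150000 nM in this assay, at which 1 of the 3 values shown sits.

As far as these compounds go, how far the true number of compound 2 lies beyond its limit remains open, and so does the full size of this step. Also open, from the compounds shown here alone, is how a carboxylic acid or a nitrile at this same place would read, and whether a saturated chain in place of the double-bonded one would change the number of compound 3.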